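This account rests on a few compounds, and the source may have more. Where it says the series, first, only, none or still open, it means among the compounds named here.

In an ADME assay on C8166 cells (Homo sapiens) for cytotoxicity, read by MTT assay (a lower number here means that less compound is tolerated, a higher number that more compound is tolerated), compound 1 `O=C(O)c1cn(-c2ccccc2)c2ccc(Cc3cccc(Cl)c3F)c(O)c2c1=O` gives 388000 nM, compound 2 `O=C(O)c1cn(-c2ccc(Br)cc2)c2ccc(Cc3cccc(Cl)c3F)c(O)c2c1=O` gives 85000 nM and compound 3 `O=C(O)c1cn(Cc2ccccc2)c2ccc(Cc3ccccc3F)c(O)c2c1=O` gives 156000 nM. Compound 2 thus lies within the scatter of compound 3 and clearly under compound 1. Compound 4 `O=C(O)c1cn(Cc2ccc(F)cc2)c2ccc(Cc3cccc(Cl)c3F)c(O)c2c1=O` differs from compound 2 by 4-fluorobenzyl in place of 4-bromophenyl on an aromatic nitrogen, with 4-fluorobenzyl in place of 4-bromophenyl on an aromatic nitrogen. For the measured compounds named here, the one measured step that bears on this is a 4.6-fold lower number from compound 1 to compound 2 (0.66 log units; beyond the scatter), which came with the bromo in place of hydrogen, and the change here removes that bromo. Compound 3, at 156000 nM, also has a benzyl group on that nitrogen. The expected step is small and upward, a 1.6-fold higher number from compound 2 to compound 4 (0.22 log units; within the scatter). For compound 4 the estimate is 140000 nM, with an expected range of 60000 nM to 330000 nM.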

Compound 4, half-maximal cytotoxic concentration: 65800 nM
Beside the measured number, compound 4's estimate is 2.1-fold (0.33 log units) above it; the range from low to high includes it.
By their numbers in this assay, from the lowest: compounds 4, 2 and 3 (each within the scatter of the next, the first and the last beyond it); then compound 1.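

In this assay, exchanging 4-bromophenyl for 4-fluorobenzyl on the aromatic nitrogen gives a 1.3-fold lower number from compound 2 to compound 4 (0.11 log units; within the scatter), so this change of group leaves the number within the scatter. Measured against the unsubstituted phenyl, the same group gives a 5.9-fold lower number from compound 1 to compound 4 (0.77 log units; beyond the scatter), which shows that the lower number at this position is not confined to the bromo-bearing group. Nothing available explains either step. Still open, going by these compounds, is how far the number would move with a plain alkyl chain or an amine-bearing group on that nitrogen.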